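Swapping chloro for bromo on a half-life scaffold

The source may hold more compounds than are shown below. What is called first, only, known or untested is meant among the compounds shown, and "the series" means these compounds.

Measured compounds:
Compound 1, `O=C(O)c1cccc(C2=C(c3cc(Br)ccc3OCc3ccc(F)cc3)CCC2)c1`, gives 0.2 h in an in vivo ADME assay on the whole organism for metabolic stability, with Rattus norvegicus as the target, at a dose of 1 mg/kg by the intravenous route; on this read-out higher numbers stand for a longer-lived compound and lower numbers for a shorter-lived compound.
Compound 2, `O=C(O)c1cccc(C2=C(c3cc(Br)ccc3OCc3ccc(F)cc3F)CCC2)c1`, gives 0.2 h in this assay.
Compound 3, `O=C(O)c1cccc(C2=C(c3cc(Cl)ccc3OCc3ccccc3)CCC2)c1`, gives 0.5 h in this assay.

Compound 3 stands highest of the three numbers in this assay, and its distance from both compound 1 and compound 2 lies beyond the usual scatter. Compound 4, `O=C(O)c1cccc(C2=C(c3cc(Br)ccc3OCc3ccccc3)CCC2)c1`, has not been measured yet; it differs from compound 3 by bromo in place of chloro on an aromatic carbon. For the measured compounds named here, no measured pair shows this exact exchange. Going by the values given here, the only single step measured, no change at the digits printed from compound 1 to compound 2 (within the scatter), concerns a different position and a different group, so it gives no direct guidance. Compound 1 and compound 2 both carry bromo at this position and both sit below compound 3, but they also carry a different benzyloxy group, so the two changes cannot be separated. On this thin basis the number for compound 4 is expected to fall between compound 3 and the two bromo compounds, a modest downward step of about a 1.4-fold lower number from compound 3 to compound 4 (0.15 log units; within the scatter). Compound 4 is therefore estimated at 0.35 h, within a range of 0.15 h to 0.8 h.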

Compound 4, half-life: 0.3 h
Compound 4: the middle estimate sits 1.2-fold (0.07 log units) above what was measured; the measured number falls inside the stated range.
By their numbers in this assay, from the lowest: compounds 1, 2, 4 and 3 (each within the scatter of the next, the first and the last beyond it).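

In this assay, the exchange of chloro for bromo, on an aromatic carbon para to a benzyloxy group, can now be read on its own, with the rest of the molecule unchanged: it gives a 1.7-fold lower number from compound 3 to compound 4 (0.22 log units; within the scatter) and so does not separate the two halogens. The benzyloxy side can also be read at last, with phenyl in place of 2,4-difluorophenyl giving a 1.5-fold higher number from compound 2 to compound 4 (0.18 log units; within the scatter) and hydrogen in place of fluoro giving a 1.5-fold higher number from compound 1 to compound 4 (0.18 log units; within the scatter), so neither fluorine pattern clearly moves the half-life on the bromo compounds. Nothing available explains why these numbers fall where they do.

The compounds shown leave open whether a methyl, methoxy or nitrile at this position would shift the half-life. They also leave open whether an amide in place of the carboxylic acid would do so.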